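A few compounds are considered here, and "the series" means these few. Any claim that something is new, unique, unknown or untested is made for them only; others in the source may bear on it.

Series notes. In a functional assay (strain AB) with Danio rerio as the target, read by microscopy, with a stated time of 1 h (on this read-out higher numbers stand for an effect only at larger amounts of compound and lower numbers for an effect already at smaller amounts), compound 1 `CCN1CCc2c(sc(NC(=O)Nc3ccc4ccccc4c3)c2C(N)=O)C1` gives 1780 nM, compound 2 `CCN1CCc2c(sc(NC(=O)Nc3ccc(Br)cc3)c2C(N)=O)C1` gives 3130 nM, and compound 3 `CC(C)(C)CN1CCc2c(sc(NC(=O)Nc3ccc(Cl)cc3)c2C(N)=O)C1` gives 5560 nM. Compound 3 holds the largest of the three numbers, though compound 2 sits within the usual scatter of it; only compound 1 lies beyond that scatter on the lower side. Compound 4 `CN1CCc2c(sc(NC(=O)Nc3ccc(Cl)cc3)c2C(N)=O)C1` has not yet been run in this assay. It differs from compound 3 in one place: hydrogen in place of tert-butyl on a saturated chain carbon bound to an amine nitrogen in a ring. For the measured compounds named here, no measured pair shows this change, so no step for it is known. For compound 4 the expectation is a step of a 1.2-fold lower number from compound 3 to compound 4 (0.09 log units; within the scatter) of modest size, in no confident direction, and likely within the scatter. Compound 4 is thus estimated at 4500 nM, with a range from 1500 nM to 14000 nM.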

Compound 4, half-maximal effective concentration: 4700 nM
Estimate against measurement, compound 4: 1.0-fold (0.02 log units) below, and the stated range covers the measured number.
By their numbers in this assay, from the lowest: compounds 1, 2, 4 and 3 (each within the scatter of the next, the first and the last beyond it).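

In this assay, for the compounds shown here, the change gives a 1.2-fold lower number from compound 3 to compound 4 (0.07 log units; within the scatter) and is the first reading at this position, where neopentyl and methyl cannot be told apart on this read-out. Compounds 1 and 2 could not show this, as neither forms a one-place pair with compound 3 or compound 4. Nothing available accounts for this result.

Still open, from the compounds shown here alone, is whether a longer chain, an amine or a carboxylic acid at this place would also stay within the scatter, and whether the step would hold with the urea partner of compound 1.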